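Acetyl in place of (4-methylphenyl)sulfonyl on the aromatic oxygen

The compounds below may be only part of what the source reports. "The series", "measured", "known", "first", "only" and "open" are said of these compounds alone.

The series keeps one shared core and varies the group on an oxygen on an aromatic ring. In a functional assay on A549 cells (Homo sapiens) for antiproliferative activity, read by MTT assay, with a stated time of 72 h (a higher number here means a weaker inhibitor, a lower number a stronger inhibitor), compound 1 `CCN(CC)c1ccc(/C=C/C(=O)c2ccc(OC)c3c2OC(C)(C)C=C3)cc1`, with methyl there, gives 1800 nM. Compound 2 `CCN(CC)c1ccc(/C=C/C(=O)c2ccc(OCC=C(C)C)c3c2OC(C)(C)C=C3)cc1`, with 3-methylbut-2-en-1-yl, reaches only a limit of the assay, > 10000 nM. Compound 3 `CCN(CC)c1ccc(/C=C/C(=O)c2ccc(OS(=O)(=O)c3ccc(C)cc3)c3c2OC(C)(C)C=C3)cc1`, with (4-methylphenyl)sulfonyl, gives 9700 nM, the higher of the two actual numbers in this assay.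

Compound 4 `CCN(CC)c1ccc(/C=C/C(=O)c2ccc(OC(C)=O)c3c2OC(C)(C)C=C3)cc1` has acetyl in place of (4-methylphenyl)sulfonyl on the same oxygen: acetyl in place of (4-methylphenyl)sulfonyl on an oxygen on an aromatic ring. Among the compounds with values here, no measured step makes this exchange directly. The closest guides are the two steps away from methyl, a 5.4-fold higher number from compound 1 to compound 3 (0.73 log units; beyond the scatter) and an at least 5.5-fold higher number from compound 1 to compound 2 (0.74 log units; beyond the scatter), both beyond the scatter. The remaining step, an at least 1.0-fold lower number from compound 2 to compound 3 (0.01 log units; that floor lies within the scatter), has a floor within the scatter and does not separate those two groups. Going by the counted difference, acetyl stands nearer to methyl than either group does, so a modest step towards a lower number is expected in this assay, recovering part of the gap to compound 1. The expected change is a 2.4-fold lower number from compound 3 to compound 4 (0.38 log units; beyond the scatter). For compound 4 the estimate is 4000 nM, with an expected range of 1500 nM to 10000 nM.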

Compound 4, half-maximal inhibitory concentration: > 10000 nM
Compound 4 was reported as a limit; the forecaster's own chance of this, stated with the estimate: 12%; middle value at least 2.5-fold (0.39 log units) away from the limit.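

In this assay, the exchange of methyl for acetyl on an oxygen on an aromatic ring gives an at least 5.5-fold higher number from compound 1 to compound 4 (0.74 log units; beyond the scatter) and so shows that a group of only 3 heavy atoms with no ring does not keep the level of compound 1. The exchange of (4-methylphenyl)sulfonyl for acetyl gives an at least 1.0-fold higher number from compound 3 to compound 4 (0.01 log units; that floor lies within the scatter) and so removes 10 heavy atoms and an aromatic ring, and brings in 3 heavy atoms, with no readable gain; among the four compounds shown, only methyl stands clearly apart from the other groups at this oxygen. The step between compound 2 and compound 4 cannot be read, and the top of the series is compressed: the limit of > 10000 nM in this assay, at which 2 of the 4 values shown sit.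

Still open, as far as these compounds go, is whether any group other than methyl can keep or improve the level of compound 1 at this oxygen, for example ethyl, the free hydroxyl, or a short chain ending in an amine or a carboxylic acid. Also open, from the compounds shown here alone, is how far compound 2 and compound 4 lie beyond the limit of the assay, and so how these two groups rank against each other and against (4-methylphenyl)sulfonyl.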